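A few compounds are considered here, and "the series" means these few. Any claim that something is new, unique, unknown or untested is made for them only; others in the source may bear on it.

Compound 1 `C=CCN1CCN(CC(=O)C(O)(c2ccccc2)C2CCCCC2)CC1` and compound 2 `C#CCN1CCN(CC(=O)C(O)(c2ccccc2)C2CCCCC2)CC1` share one core and differ only in the group on an amine nitrogen in a ring. In a functional assay on ileum for antagonist activity at muscarinic acetylcholine receptor M3 (Cavia porcellus) (a lower number here means a stronger inhibitor, a higher number a weaker inhibitor), compound 1 gives 25.6 nM, and compound 2 gives 260 nM. The step of a 10-fold higher number from compound 1 to compound 2 (1.01 log units; beyond the scatter) shows that a small change at this nitrogen can move the number a long way. Going by the values given here, compound 2 thus stands with the higher of the two numbers known so far, and compound 1 with the lower. Compound 3 `CCOC(=O)N1CCN(CC(=O)C(O)(c2ccccc2)C2CCCCC2)CC1` is the next compound, as yet unmeasured, and carries ethoxycarbonyl in place of propargyl on an amine nitrogen in a ring. Among the compounds with values here, only one measured step bears on this change, and it alters the same position with a different group, so it gives direction poorly; the expectation is a further shift towards a higher number, a 2.3-fold higher number from compound 2 to compound 3 (0.36 log units; beyond the scatter), because the step of a 10-fold higher number from compound 1 to compound 2 (1.01 log units; beyond the scatter) already moved strongly away from compound 1. For compound 3 the estimate in this assay is therefore 600 nM, with a range from 100 nM to 4000 nM.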

Compound 3, antagonist equilibrium constant: > 10000 nM
Compound 3: a limit, no number (the forecaster's own chance of this, stated with the estimate: 5%); at least 16-fold (1.22 log units) between middle value and limit.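

In this assay, compound 3 gives only a limit of the assay, not a number: the limit of > 10000 nM in this assay, at which 1 of the 3 values shown sits. Placing ethoxycarbonyl on the amine nitrogen in the ring gives an at least 38-fold higher number from compound 2 to compound 3 (1.58 log units; beyond the scatter) and an at least 390-fold higher number from compound 1 to compound 3 (2.59 log units; beyond the scatter), so both steps go further than the earlier swap among small carbon groups, a 10-fold higher number from compound 1 to compound 2 (1.01 log units; beyond the scatter). This position therefore allows a much larger loss than allyl and propargyl alone revealed, and that loss comes with the only group shown here that carries oxygen atoms and hydrogen-bond acceptors.

Going by these compounds, how far compound 3 lies beyond its limit stays unknown, so the true size of both new steps does too. The compounds shown cannot separate the carbonyl from the size of the group; a plain propyl chain, an acetyl group or a longer alkyl chain on this nitrogen would bear on that question.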